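Cyclobutyl replacing isopropyl on the core nitrogen of compound 1

A few compounds are considered here, and "the series" means these few. Any claim that something is new, unique, unknown or untested is made for them only; others in the source may bear on it.

Within the data shown here, compound 1 `CC(C)n1cnc2c(N)ncnc21` is the only member of this small set with a number rather than a limit: in an assay on CHO cells for displacement of a labelled ligand from adenosine receptor A1 (Homo sapiens) (on this read-out higher numbers stand for weaker inhibition and lower numbers for stronger inhibition), compound 1 gives 4300 nM. Compound 2 `CCC(C)n1cnc2ncnc(N)c21` reaches only the limit of this assay, giving > 100000 nM. Compound 3 `CC(C)Cn1cnc2ncnc(N)c21` likewise sits at the limit, giving > 100000 nM. The step from compound 2 to compound 3, a step that the two limits leave unreadable from compound 2 to compound 3, therefore cannot be sized; both values rest on (the limit of > 100000 nM in this assay, at which 2 of the 3 values shown sit).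

Compound 4 `Nc1ncnc2c1ncn2C1CCC1` differs from compound 1 by cyclobutyl in place of isopropyl on an aromatic nitrogen. Among the measured compounds shown here, no measured step bears directly on this change. The only pattern among the measured compounds is that the two larger branched chains, the sec-butyl of compound 2 and the isobutyl of compound 3, fall to the limit where the isopropyl of compound 1 still gives a number; how far beyond the limit they lie is not known, so the size of that loss cannot be stated.

Given this, compound 4 is expected to be somewhat weaker than compound 1, with the step of a 2.1-fold higher number from compound 1 to compound 4 (0.32 log units; beyond the scatter) estimated to run toward weaker inhibition. Compound 4 is accordingly estimated at 9000 nM in this assay, within a range from 2000 nM to 60000 nM.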

Compound 4, inhibition constant: 8700 nM
The estimate for compound 4 lay 1.0-fold (0.01 log units) above the measured number; the measured number falls inside the stated range.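

In this assay, among these compounds, the result gives the first readable step at this position on the aromatic nitrogen: replacing isopropyl with cyclobutyl, which adds one carbon and a four-membered ring, gives a 2.0-fold higher number from compound 1 to compound 4 (0.31 log units; beyond the scatter). This is a modest loss, and it shows that a larger group here does not by itself take the read-out to the limit, since the cyclobutyl of compound 4 still gives a number where the sec-butyl of compound 2 and the isobutyl of compound 3 do not. How far compound 4 lies from those two open-chain compounds cannot be read: the limit of > 100000 nM in this assay, at which 2 of the 4 values shown sit.

The compounds shown leave open whether the ring itself is what keeps a number at this position, and whether a cyclopropyl or cyclopentyl group on the same nitrogen would stay near compound 4 or fall to the limit. They also leave open how an unbranched chain such as n-propyl or n-butyl would compare with isopropyl and cyclobutyl on the shared core.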